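A few compounds are considered here, and "the series" means these few. Any claim that something is new, unique, unknown or untested is made for them only; others in the source may bear on it.

Compound 1 `CC(C)[C@@H]1CC[C@@H](C)C[C@@]12N(C)C(=O)[C@@H]1[C@H]3C(=O)N(c4ccccc4)C(=O)[C@H]3ON12` is the reference point for this step. In a functional assay, read by spectrophotometry, with a stated time of 2 h, tested at 2.5 mg/mL (a higher number here means a stronger effect of the compound at the concentration tested, a lower number a weaker effect), compound 1 gives 58.6%, the lowest of the two numbers recorded so far. Among the compounds with values here, the only other measured member of the series is compound 2 `COc1ccc(N2C(=O)[C@H]3[C@H](ON4[C@@H]3C(=O)N(C)[C@@]43C[C@H](C)CC[C@H]3C(C)C)C2=O)cc1`, which in this assay gives 71.5%. Within the data shown here, the single measured step, a number 12.9 percentage points higher from compound 1 to compound 2 (beyond the scatter), alters the substitution on the aromatic ring carried by the amide-type nitrogen in the ring.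

The unmeasured compound 3 `CC(C)[C@@H]1CC[C@@H](C)C[C@@]12N(C)C(=O)[C@@H]1[C@H]3C(=O)N(c4ccc5ccccc5c4)C(=O)[C@H]3ON12` differs from compound 1 by naphthalen-2-yl in place of phenyl on an amide-type nitrogen in a ring. Among the measured compounds shown here, no measured step exchanges one aromatic ring for a larger one, so the step from compound 1 to compound 2 is the nearest comparison available; it shows that a change on this aromatic ring moved the read-out upward by a modest amount. Without a direct precedent, only a small upward shift in this assay is expected for compound 3, and the estimated step of a number 5.4 percentage points higher from compound 1 to compound 3 (within the scatter) is taken to lie near the edge of the scatter.

For compound 3 the expected activity in this assay is 64%, with a range from 46% to 80%.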

Compound 3, a percentage reported as activity, at one concentration (the size of the read-out at that concentration, not a potency): 47.9%
Compound 3: middle estimate off by 16.1 percentage points, on the high side; the measured number falls inside the stated range.
By their numbers in this assay, from the lowest: compound 3; then compound 1; then compound 2.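

The aromatic group on the amide-type nitrogen in a ring can move the read-out in either direction in this assay: the change to naphthalen-2-yl in place of phenyl gives a number 10.7 percentage points lower from compound 1 to compound 3 (beyond the scatter) and so runs against the upward step seen with 4-methoxyphenyl. Naphthalen-2-yl in place of 4-methoxyphenyl gives a number 23.6 percentage points lower from compound 2 to compound 3 (beyond the scatter) and is the largest step among the three compounds, which shows that this position separates the compounds clearly and that a larger aromatic group does not by itself raise the number. Nothing measured here accounts for the direction or size of either step.

As far as these compounds go, only phenyl, 4-methoxyphenyl and naphthalen-2-yl appear at this nitrogen, so it remains open how a 3-methoxyphenyl, a 4-hydroxyphenyl, a 4-aminophenyl or a naphthalen-1-yl group would read, and whether the methoxy group itself or its place on the ring matters. From the compounds shown here alone, the shared core stays the same in all three compounds, and the read-out is taken at a single concentration, so whether the same order holds at other concentrations or with other groups on the core also remains open.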